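The source may report more compounds than this note shows. Statements on the series, on what has been measured and on what is new or still open speak of the compounds shown alone.

Working notes on the series. In a functional assay on HOS cells (Homo sapiens) for antiproliferative activity, read by sulforhodamine B assay (on this read-out lower numbers stand for stronger inhibition of growth and higher numbers for weaker inhibition of growth), compound 1 `CC[C@H]1O[C@H](COCc2ccccc2)[C@@H](OCc2ccccc2)[C@H](OCc2ccccc2)[C@H]1O` gives > 50000 nM, which is a limit of the assay and not a number. Compound 2 `CCC[C@@H]1O[C@H](CO)[C@@H](O)[C@H](O)[C@H]1O` gives > 50000 nM in this assay, also only a limit. Compound 3 `C[C@@H]1O[C@H](COCc2ccccc2)[C@@H](OCc2ccccc2)[C@H](OCc2ccccc2)C1=O` stands at > 50000 nM in this assay, again a limit rather than a number, in line with the limit of > 50000 nM in this assay, at which 3 of the 3 values shown sit. Compound 4 `C=CC[C@@H]1O[C@H](COCc2ccccc2)[C@@H](OCc2ccccc2)[C@H](OCc2ccccc2)C1=O` is not yet measured; it differs from compound 3 by vinyl in place of hydrogen on a saturated chain carbon bound to a saturated ring carbon. Going by the values given here, no step between measured compounds is available, so the expectation for compound 4 in this assay rests on compound 3 alone. The expected step is a number no higher from compound 3 to compound 4 (the limit leaves the size open), none beyond the scatter. Compound 4 is therefore estimated at 50000 nM, with a range from 20000 nM to 100000 nM, most likely reported again as a limit.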

Compound 4, concentration for 50% growth inhibition: 7600 nM
Compound 4: the middle estimate sits 6.6-fold (0.82 log units) above what was measured; the whole stated range lies above it.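

In this assay, going by these compounds alone, the saturated chain carbon bound to a saturated ring carbon proves to be a place where a change can move the read-out, which the earlier compounds did not show: vinyl in place of hydrogen there, or methyl to allyl when cut one bond further out, gives an at least 6.5-fold lower number from compound 3 to compound 4 (0.81 log units; beyond the scatter). Compound 4 is the only compound here with a number rather than a limit, so the step has a lower bound but no fixed size: the limit of > 50000 nM in this assay, at which 3 of the 4 values shown sit.

The compounds shown leave open whether the double bond or the added chain length carries the step. On these data alone, how a propyl chain, a longer chain or an amine would read at this place also remains open.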